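The compounds below may be only part of what the source reports. "The series", "measured", "known", "first", "only" and "open" are said of these compounds alone.

Going by the values given here, compound 1 `CCOC(=O)C1=C(N/C=N/c2cccnc2Cl)Nc2[nH]nc(C)c2C1c1ccc(N(C)C)cc1` is, in an ADME assay on WI-38 cells (Homo sapiens) for cytotoxicity, read by MTT assay, with a stated time of 48 h (on this read-out lower numbers stand for stronger inhibition and higher numbers for weaker inhibition), the higher of the two numbers measured so far, giving 74500 nM. Compound 2 `CCOC(=O)C1=C(N/C=N/c2ncc(-c3ccccc3)s2)Nc2[nH]nc(C)c2C1c1ccc(N(C)C)cc1` in this assay gives 33500 nM, and the single step shown, a 2.2-fold lower number from compound 1 to compound 2 (0.35 log units; beyond the scatter), is the only measured change at the double-bonded nitrogen of the shared core. Compound 3 `CCOC(=O)C1=C(N)Nc2[nH]nc(C)c2C1c1ccc(N(C)C)cc1` is not yet measured; it differs from compound 1 by a hydrogen atom in place of a group of 9 heavy atoms (6 carbon, 2 nitrogen, 1 chlorine; one six-membered aromatic ring with 1 hetero atom), on an amine nitrogen. Among the compounds with values here, the measured step exchanges one aryl group on that nitrogen for another, whereas here the whole group is removed, so it bears only loosely on this change and gives no precedent for the bare amine. Nothing in the measured pair points to a large move in either direction. For compound 3 the step of a 1.3-fold higher number from compound 1 to compound 3 (0.11 log units; within the scatter) is expected, a slightly higher number at most, within or barely beyond the scatter. The estimate for compound 3 in this assay is 95000 nM, with a range from 35000 nM to 260000 nM.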

Compound 3, half-maximal inhibitory concentration: 84000 nM
The estimate for compound 3 lay 1.1-fold (0.05 log units) above the measured number; the measured number falls inside the stated range.
By their numbers in this assay, from the lowest: compound 2; then compounds 1 and 3 (each within the scatter of the next).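

In this assay, a hydrogen atom in place of the group of 9 heavy atoms on the amine nitrogen gives a 1.1-fold higher number from compound 1 to compound 3 (0.05 log units; within the scatter), so the bare amine and the group carrying the six-membered aromatic ring cannot be told apart on this read-out. Going by these compounds alone, the earlier exchange of one aryl group for another showed only that this substituent can be varied; this result adds that removing this particular group leaves the number unchanged within the scatter, while a 2.2-fold lower number from compound 1 to compound 2 (0.35 log units; beyond the scatter) remains the only step beyond it. No measurement available here bears on the reason for either result.

From the compounds shown here alone, it remains open whether the lower number of compound 2 comes from the 1,3-thiazole ring or from its phenyl group. Going by these compounds, the effect of an acetyl group or a plain phenyl group on that nitrogen also remains open.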